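The compounds below may be only part of what the source reports. "The series", "measured", "known", "first", "only" and "open" are said of these compounds alone.

Measured in a toxicity assay on Vero cells (Chlorocebus sabaeus) for cytotoxicity, read by MTT assay (a higher number here means a weaker inhibitor, a lower number a stronger inhibitor), so far:
Compound 1 `COC(=O)NC(=O)c1ccsc1NC(=O)c1ccc(S(=O)(=O)N2CCCC2)cc1` gives 39.5 ug/mL
Compound 2 `COC(=O)NC(=O)c1ccsc1NC(=O)c1ccc(S(=O)(=O)NC2CCCCC2)cc1` gives > 64 ug/mL as a limit of the assay
Compound 3 `CCOC(=O)NC(=O)c1ccsc1NC(=O)c1ccc(S(=O)(=O)N2CCCC2)cc1` gives 58.2 ug/mL

The two numbers stand level within the scatter (a 1.5-fold higher number from compound 1 to compound 3 (0.17 log units; within the scatter)). The reading for compound 2 is a limit (the limit of > 64 ug/mL in this assay, at which 1 of the 3 values shown sits). Compound 4 `CCOC(=O)NC(=O)c1ccsc1NC(=O)c1ccc(S(=O)(=O)Nc2ccc(F)cc2)cc1` carries (4-fluorophenyl)amino in place of pyrrolidin-1-yl on a sulfonyl sulfur. The measured step that bears on this change also replaces pyrrolidin-1-yl on a sulfonyl sulfur (an at least 1.6-fold higher number from compound 1 to compound 2 (0.20 log units; that floor lies within the scatter)). The step between the two numbers above lies at a different place and says little here. No step beyond the scatter is therefore expected in this assay, and the reading may again be a limit. The expected step is a 1.0-fold higher number from compound 3 to compound 4 (0.01 log units; within the scatter) in size. For compound 4 the estimate is 60 ug/mL with an expected range from 30 ug/mL to 120 ug/mL for the measurement.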

Compound 4, half-maximal inhibitory concentration: 20.5 ug/mL
Estimate against measurement, compound 4: 2.9-fold (0.47 log units) above, outside the stated range (below it).
By their numbers in this assay, from the lowest: compounds 4, 1 and 3 (each within the scatter of the next, the first and the last beyond it). At a limit, above all of these: compound 2.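

In this assay, the group on the sulfonyl sulfur can move the number beyond the scatter, with (4-fluorophenyl)amino in place of pyrrolidin-1-yl: a 2.8-fold lower number from compound 3 to compound 4 (0.45 log units; beyond the scatter). The earlier step at this place could not show this, as compound 2 is held at a limit and gives no number: the limit of > 64 ug/mL in this assay, at which 1 of the 4 values shown sits.

The compounds shown leave open whether the fluorine takes part in this step, which a plain phenylamino group at this place would test. They also leave open whether the step would recur on compound 1, which differs from compound 3 elsewhere.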